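Trading Propoxy for Methyl on a Fused Polycyclic Core

The compounds below may be only part of what the source reports. "The series", "measured", "known", "first", "only" and "open" are said of these compounds alone.

Measured compounds:
- compound 1, `CC1COC2(C)Oc3c(c4c(c5c3CC3C(C)COC3(C)O5)CC3C(C)COC3(C)O4)CC12`: 6000 nM
- compound 2, `CCCOc1cc2c(c3c1C[C@@H]1[C@@H](C)CO[C@]1(C)O3)C[C@@H]1[C@@H](C)CO[C@]1(C)O2`: 43000 nM
- compound 3, `CC1COC2(C)Oc3cc(O)c4c(c3CC12)OC1(C)OCC(C)C1C4`: 19000 nM

In a functional assay on aorta (Rattus norvegicus, strain Sprague-Dawley) for inhibition (on this read-out higher numbers stand for an effect only at larger amounts of compound and lower numbers for an effect already at smaller amounts), compound 2 gives 43000 nM, the highest of the three numbers. Its nearest neighbour is compound 3 with 19000 nM, and compound 1, at 6000 nM, stands furthest away from it; both of these gaps lie beyond the usual scatter of this assay, so compound 2 is the weakest of the three measured compounds in this assay.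

Compound 4, `Cc1cc2c(c3c1C[C@@H]1[C@@H](C)CO[C@]1(C)O3)C[C@@H]1[C@@H](C)CO[C@]1(C)O2`, has not been measured in this assay. It differs from compound 2 in one place: methyl in place of propoxy on an aromatic carbon. Going by the values given here, no direct step between two measured compounds that would match this change is available, so any expectation rests on the spread of the three values themselves, which runs from compound 1 at the low end to compound 2 at the high end.

For this assay a modest step toward lower numbers is expected, estimated as a 2.2-fold lower number from compound 2 to compound 4 (0.33 log units; beyond the scatter). A result within the usual scatter would not be surprising. On that basis compound 4 is estimated at 20000 nM in this assay, with a range from 6000 nM to 60000 nM.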

Compound 4, half-maximal effective concentration: 40000 nM
Compound 4: middle estimate off by 2.0-fold (0.30 log units), on the low side; measured number inside the range.
By their numbers in this assay, from the lowest: compound 1; then compound 3; then compounds 4 and 2 (each within the scatter of the next).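

In this assay, putting methyl in place of propoxy on this aromatic carbon yields a 1.1-fold lower number from compound 2 to compound 4 (0.03 log units; within the scatter) and so leaves the two values indistinguishable. Going by these compounds alone, the earlier compounds offered no step at this position, and this pair gives the first direct reading of it. The four heavy atoms of propoxy, with its one hydrogen-bond acceptor, give way to the single heavy atom of methyl, with no acceptor, and this exchange leaves no readable mark on the number. Nothing available explains why the read-out stays level across this change.

Propoxy and methyl are the only two groups compared at this place, so these compounds cannot show whether the level result extends to other groups on this aromatic carbon. An amine, a carboxylic acid or a longer chain such as hexyloxy at the same place could show whether the number responds to any group there, or whether this position stays as flat as this single pair suggests.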